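Methoxy added to the carbonyl-side ring of compound 3

The source may report more compounds than this note shows. Statements on the series, on what has been measured and on what is new or still open speak of the compounds shown alone.

Compound 3 `COc1ccc(C(=O)/C=C/c2cc(-c3cc(OC)c(OC)c(OC)c3)n[nH]2)cc1OC` gives the lowest number of the three measured in a functional assay on SK-OV-3 cells (Homo sapiens) for inhibition, read by sulforhodamine B assay, with a stated time of 48 h (on this read-out higher numbers stand for weaker inhibition of growth and lower numbers for stronger inhibition of growth), at 7820 nM. Within the data shown here, compound 1 `COc1cc(-c2cc(/C=C/C(=O)c3ccc(Cl)c(Cl)c3)[nH]n2)cc(OC)c1OC` gives 18800 nM and compound 2 `COc1ccc(-c2cc(/C=C/C(=O)c3cc(OC)c(OC)c(OC)c3)[nH]n2)cc1OC` gives 19000 nM; the only measured single-point step is a 2.4-fold lower number from compound 1 to compound 3 (0.38 log units; beyond the scatter). Compound 4 `COc1cc(C(=O)/C=C/c2cc(-c3cc(OC)c(OC)c(OC)c3)n[nH]2)cc(OC)c1OC` differs from compound 3 by methoxy in place of hydrogen on an aromatic carbon. Among the measured compounds shown here, no measured step addresses a methoxy entering at this position, and the step from compound 1 to compound 3 concerns a different change on the carbonyl carbon, so it does not carry over. With nothing to support a clear shift, the expected step for compound 4 in this assay is a 1.0-fold higher number from compound 3 to compound 4 (0.01 log units; within the scatter), within the scatter. Compound 4 is therefore estimated at 8000 nM, range 3000 nM to 22000 nM.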

Compound 4, concentration for total growth inhibition: 11100 nM
Estimate against measurement, compound 4: 1.4-fold (0.14 log units) below; measured number inside the range.
By their numbers in this assay, from the lowest: compounds 3, 4, 1 and 2 (each within the scatter of the next, the first and the last beyond it).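

In this assay methoxy in place of hydrogen on the carbonyl-side ring gives a 1.4-fold higher number from compound 3 to compound 4 (0.15 log units; within the scatter) and so leaves the number within the scatter. The same change on the other six-membered aromatic ring gives a 1.7-fold lower number from compound 2 to compound 4 (0.23 log units; within the scatter) and is also within the scatter, so at neither place does this added methoxy produce a readable shift. No evidence at hand bears on these results.

From the compounds shown here alone, whether an amine, a hydroxyl or a longer chain such as ethoxy at this position would give a step beyond the scatter remains open.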